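Difluoromethyl to trifluoromethyl in the oral exposure series

The source may report more compounds than this note shows. Statements on the series, on what has been measured and on what is new or still open speak of the compounds shown alone.

Measured in an ADME assay on the whole organism (Macaca fascicularis) for pharmacokinetics, with stated times of 24 h and 72 h, at a dose of 1 mg/kg by the oral route; on this read-out lower numbers stand for lower exposure and higher numbers for higher exposure at the dose given:
- compound 1 `Fc1cc2nc(-c3cncnc3C(F)F)n(C3CC3)c2cc1F`: 2840 ng.h/mL
- compound 2 `N#Cc1ccc2nc(-c3cncnc3C(F)F)n(C3CC3)c2n1`: 10100 ng.h/mL

Of the two measured compounds, compound 2 stands highest at 10100 ng.h/mL, and its nearest neighbour, compound 1, lies lower at 2840 ng.h/mL, a gap beyond the usual scatter. The next structure is compound 3 `N#Cc1ccc2nc(-c3cncnc3C(F)(F)F)n(C3CC3)c2n1`, which departs from compound 2 in one place: fluoro in place of hydrogen on a saturated chain carbon bound to an aromatic carbon and two fluorine atoms, or difluoromethyl to trifluoromethyl. Within the data shown here, no measured pair here shows this change, so its size has no direct precedent. In this assay, no step beyond the scatter is expected. The expected change is a 1.1-fold higher number from compound 2 to compound 3 (0.04 log units; within the scatter), which stays within the scatter. Compound 3 is estimated at 11000 ng.h/mL, with an expected range of 4500 ng.h/mL to 26000 ng.h/mL.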

Compound 3, area under the concentration-time curve: 3340 ng.h/mL
Compound 3: the middle estimate sits 3.3-fold (0.52 log units) above what was measured, outside the stated range (below it).
By their numbers in this assay, from the lowest: compounds 1 and 3 (each within the scatter of the next); then compound 2.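

In this assay, among these compounds, difluoromethyl to trifluoromethyl gives a 3.0-fold lower number from compound 2 to compound 3 (0.48 log units; beyond the scatter), and this is the first change in one place that can be read. A single added fluoro on the saturated chain carbon bound to an aromatic carbon thus moves oral exposure beyond the scatter, so on the core of compound 2 this position is not silent on this read-out. No measured property accompanies the step, and nothing at hand accounts for it.

Whether the same change would read alike on the core of compound 1 remains open, as the compounds shown hold no such pair on that core. Also open, on these data alone, is how a methyl group, an ethyl group or a methoxy group would read in place of difluoromethyl.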